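The source may report more compounds than this note shows. Statements on the series, on what has been measured and on what is new or still open speak of the compounds shown alone.

Three compounds of one series have been examined so far in an assay on HEK293 cells for agonist activity at transient receptor potential cation channel subfamily M member 8 (Homo sapiens), read by fluorescence and calcium flux, with a stated time of 15 min; a lower number here means that less compound is needed, a higher number that more compound is needed for the effect. Compound 1 `CCN(Cc1ccsc1)C(=O)COc1ccc(C)cc1` carries a thiophen-3-yl group on the saturated chain carbon bound to the amide-type nitrogen, and in this assay compound 1 gives 88 nM. Compound 2 `CCN(Cc1cc[nH]n1)C(=O)COc1ccc(C)cc1` carries a pyrazolyl group at the same place, and in this assay compound 2 is reported as "not active" (no number reported), without a number. Compound 3 `CCN(Cc1ccncc1)C(=O)COc1ccc(C)cc1` carries a pyridin-4-yl group there, and in this assay compound 3 is likewise reported as "not active" (no number reported), again without a number. So compound 3 stands with compound 2 among the entries for which no value could be given, while compound 1 is the only one of the three with a measured concentration.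

The next compound, compound 4 `CCN(Cc1cccs1)C(=O)COc1ccc(C)cc1`, differs from compound 3 in one place: thiophen-2-yl in place of pyridin-4-yl on a saturated chain carbon bound to an amide-type nitrogen. The resulting structure is a close relative of compound 1, differing from it only in the point of attachment of the thiophene.

Among the measured compounds shown here, no step between measured compounds shows what this change does. Still, the change moves compound 4 away from the inactive compound 3 and toward compound 1, which in this assay gives 88 nM, so a large gain in this assay is expected, from no measurable activity to a value of the same order as that of compound 1. Compound 4 is therefore expected to give about 150 nM in this assay, with a range from 40 nM to 600 nM.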

Compound 4, half-maximal effective concentration: 8 nM
Beside the measured number, compound 4's estimate is 19-fold (1.27 log units) above it, outside the stated range (below it).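

In this assay, thiophen-2-yl in place of thiophen-3-yl on a saturated chain carbon bound to an amide-type nitrogen gives an 11-fold lower number from compound 1 to compound 4 (1.04 log units; beyond the scatter), a large change beyond the scatter. Among the compounds shown here, the earlier compounds showed only that a thiophen-3-yl group here came with a number, while the pyrazolyl and pyridin-4-yl groups came with none; this pair shows that the point of attachment of one and the same ring also matters at this position, whereas the change from compound 3 to compound 4 cannot be read as a step, as compound 3 has no number. No measurement among the data given bears on why the point of attachment matters so much.

The compounds shown leave open whether the sulfur-containing ring is needed at all, as they do not tell how a furan-2-yl or a phenyl group would behave at this position. They also leave open how far the result carries over to the rest of the structure, for instance whether the same preference for thiophen-2-yl would hold with a propyl group in place of the ethyl group.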